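Dimethoxyphenyl sulfonamide on a shared indazole-indole amine core

This account rests on a few compounds, and the source may have more. Where it says the series, first, only, none or still open, it means among the compounds named here.

Measured compounds:
compound 1, `CN(C(=O)c1ccc(Cl)cc1)c1ccc2[nH]c(-c3n[nH]c4ccccc34)cc2n1`, 2220 nM
compound 2, `COc1cccc(C(=O)N(C)c2ccc3[nH]c(-c4n[nH]c5ccccc45)cc3n2)c1`, 14900 nM
compound 3, `CN(c1ccc2[nH]c(-c3n[nH]c4ccccc34)cc2n1)S(=O)(=O)c1ccccc1`, 14000 nM

Of the compounds shown here, three sharing one core have been tested in a functional assay on A549 cells (Homo sapiens) for antiproliferative activity, read by MTT assay, with a stated time of 72 h; on this read-out higher numbers stand for weaker inhibition and lower numbers for stronger inhibition. Compound 1, with a 4-chlorophenyl carbonyl on the ring nitrogen, gives the lowest number of the three. Compound 2 gives 14900 nM and compound 3 gives 14000 nM; these two lie within the scatter of each other, so compound 3 stands together with compound 2 at the weaker end, and the step of a 6.3-fold higher number from compound 1 to compound 3 (0.80 log units; beyond the scatter) separates it from compound 1.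

Compound 4, `COc1ccc(S(=O)(=O)N(C)c2ccc3[nH]c(-c4n[nH]c5ccccc45)cc3n2)c(OC)c1`, differs from compound 3 by 2,4-dimethoxyphenyl in place of phenyl on a sulfonyl sulfur. Among the compounds with values here, no measured step touches the aryl group on the sulfonyl sulfur. Within the data shown here, the only step that changes an aryl substituent is a 6.7-fold higher number from compound 1 to compound 2 (0.83 log units; beyond the scatter), but it sits on a carbonyl, not a sulfonyl, and swaps a chloro for a methoxy rather than adding two methoxy groups, so it bears only loosely on this case. In this assay compound 4 is therefore expected to move little, with the step of a 1.1-fold higher number from compound 3 to compound 4 (0.06 log units; within the scatter) likely within the scatter. Compound 4 is estimated at 16000 nM, in the range 6000 nM to 42000 nM.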

Compound 4, half-maximal inhibitory concentration: 25900 nM
Compound 4: middle estimate off by 1.6-fold (0.21 log units), on the low side; low and high end bracket the measured number.
By their numbers in this assay, from the lowest: compound 1; then compounds 3, 2 and 4 (each within the scatter of the next).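

On a sulfonyl sulfur whose other neighbour is the sulfonamide nitrogen, 2,4-dimethoxyphenyl in place of phenyl gives, in this assay, a 1.9-fold higher number from compound 3 to compound 4 (0.27 log units; within the scatter), the only reading shown of a change to the aryl group at this position. The two compounds therefore cannot be told apart here, so this exchange, which takes the group from 6 to 10 heavy atoms and brings in 2 hydrogen-bond acceptors, has no effect that this assay can resolve. No supporting measurement is available that would help interpret this result.

This single pair cannot show how other aryl groups behave on the sulfonyl sulfur. As far as these compounds go, it remains open whether 4-chlorophenyl, the group carried on the carbonyl of compound 1, would read differently there, and what a phenyl bearing an amine or a carboxylic acid would give.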